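A few compounds are considered here, and "the series" means these few. Any claim that something is new, unique, unknown or untested is made for them only; others in the source may bear on it.

Of the compounds shown here, three built on a shared core have so far been tested in a functional assay on MCF7 cells (Homo sapiens) for antiproliferative activity, read by CCK-8 assay, with a stated time of 72 h; on this read-out lower numbers stand for stronger inhibition and higher numbers for weaker inhibition. Compound 1 `COc1cccc(C(=O)Nc2cccc(-c3oc4cc(-c5ccc(F)cc5)ccc4c(=O)c3O)c2)c1` gives 15300 nM. Compound 2 `CCc1ccc(C(=O)Nc2cccc(-c3oc4cc(-c5ccc(F)cc5)ccc4c(=O)c3O)c2)cc1` gives 22800 nM. Compound 3 `COc1ccc(C(=O)Nc2cccc(-c3oc4cc(-c5ccc(F)cc5)ccc4c(=O)c3O)c2)c(F)c1` gives 20000 nM. Compound 3 has the second highest of the three numbers, but the gaps to the other two are small: a 1.1-fold lower number from compound 2 to compound 3 (0.06 log units; within the scatter) and a 1.3-fold higher number from compound 1 to compound 3 (0.12 log units; within the scatter), so all three values sit within the usual scatter of one another.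

Compound 4 `CCCc1ccc(C(=O)Nc2cccc(-c3oc4cc(-c5ccc(F)cc5)ccc4c(=O)c3O)c2)cc1` has not yet been measured. It differs from compound 3 in one place: 4-propylphenyl in place of 2-fluoro-4-methoxyphenyl on a carbonyl carbon.

Going by the values given here, two measured steps bear on this change. The step of a 1.1-fold lower number from compound 2 to compound 3 (0.06 log units; within the scatter) is close to the reverse of it, exchanging an alkyl-bearing ring for the fluorine- and methoxy-bearing one, and it stayed within the scatter. The step of a 1.5-fold higher number from compound 1 to compound 2 (0.17 log units; within the scatter) also traded a methoxy-bearing ring for an alkyl-bearing one without leaving the scatter. Nothing among these three compounds indicates that going from ethyl to propyl on the ring would move the number beyond the scatter. Compound 4 is therefore expected to land close to compound 3, with an expected step of a 1.1-fold higher number from compound 3 to compound 4 (0.04 log units; within the scatter). For compound 4 the estimated value in this assay is 22000 nM, with an expected range from 10000 nM to 45000 nM.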

Compound 4, half-maximal inhibitory concentration: 36800 nM
Compound 4: middle estimate off by 1.7-fold (0.22 log units), on the low side, within the range that was stated.
By their numbers in this assay, from the lowest: compounds 1, 3, 2 and 4 (each within the scatter of the next, the first and the last beyond it).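

Going by these compounds alone, compound 4 gives the first step at this position that leaves the scatter in this assay, though only modestly: 4-propylphenyl in place of 3-methoxyphenyl on the carbonyl carbon (a 2.4-fold higher number from compound 1 to compound 4 (0.38 log units; beyond the scatter)). The other two new steps stay within the scatter, one for 4-propylphenyl in place of 2-fluoro-4-methoxyphenyl (a 1.8-fold higher number from compound 3 to compound 4 (0.26 log units; within the scatter)) and one for methyl in place of hydrogen on the chain, which turns ethyl into propyl (a 1.6-fold higher number from compound 2 to compound 4 (0.21 log units; within the scatter)), so the ethyl and propyl pair alone supports no trend with chain length. Thus, only the two ends of the series can be told apart, and nothing measured here gives a reason for the gap between them.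

As far as these compounds go, it remains open whether a butyl chain or a longer one would carry the number further in the same direction, or whether the propyl result is simply part of the scatter. Also unsettled is what a plain phenyl ring, or a ring bearing an amine or a carboxylic acid, would do at this position on the carbonyl carbon.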